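One Inverted Ring Carbon, Same Atoms Throughout

The source may hold more compounds than are shown below. What is called first, only, known or untested is meant among the compounds shown, and "the series" means these compounds.

Of the compounds shown here, two sharing the same core have been tested in a functional assay on WEHI-164 cells (Mus musculus) for cytotoxicity; a lower number here means a stronger inhibitor, a higher number a weaker inhibitor. Compound 1 `CCCCC(CC)C/C(C)=C/[C@@]1(CC)C[C@@H](CC)[C@@H](CC(=O)OC)OO1` gives 9.5 ug/mL. Compound 2 `CC/C=C/C(CC)C/C(C)=C/[C@]1(CC)C[C@H](CC)[C@H](CC(=O)OC)OO1` gives 7.1 ug/mL, the lower of the two numbers, although its gap to compound 1 lies within the scatter, so neither can be called the stronger of the pair.

Compound 3 `CC/C=C/C(CC)C/C(C)=C/[C@]1(CC)C[C@@H](CC)[C@H](CC(=O)OC)OO1` is the next step from compound 2. the two compounds have the same atoms and bonds; at least one stereo element is drawn with a configuration in one of them and without one in the other: 1 of 6 stereo elements differ; a stereocentre at a saturated ring carbon is drawn S in compound 2 and R in compound 3 No measured pair here shows what such an inversion does, so the size of this step has no precedent among these compounds. A single stereocentre can leave the number where it is or move it either way; with nothing to anchor the direction, the expected outcome is a step not far beyond the scatter, leaning toward a weaker inhibitor. Compound 3 is estimated at 9.5 ug/mL, within 3.5 ug/mL to 28 ug/mL, which means an expected step of a 1.3-fold higher number from compound 2 to compound 3 (0.13 log units; within the scatter).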

Compound 3, half-maximal inhibitory concentration: 8.2 ug/mL
For compound 3 the middle estimate is 1.2-fold (0.06 log units) above the measured one; measured number inside the range.
By their numbers in this assay, from the lowest: compounds 2, 3 and 1 (each within the scatter of the next).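

Going by these compounds alone, compound 2 and compound 3 form the first pair here that differs in only one place, so the effect of a single stereocentre can now be read directly. In this assay, changing a saturated ring carbon from S to R gives a 1.2-fold higher number from compound 2 to compound 3 (0.06 log units; within the scatter), so this assay does not separate the two drawn configurations at this position. One caution applies to reading the pair as a clean inversion: the fact that one of compounds 2 and 3 is drawn with a defined configuration and the other without, at the place where they differ.

The compounds shown leave open whether changing any of the other stereo elements would also leave the number within the scatter. They also leave open what a carboxylic acid in place of the methyl ester would give, and whether the configuration at this ring carbon would matter with that group present.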